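Replacing the 4-hydroxypiperidin-1-yl group of compound 3

The source may report more compounds than this note shows. Statements on the series, on what has been measured and on what is new or still open speak of the compounds shown alone.

Measured compounds (an ADME assay on microsomes from liver (Mus musculus) for metabolic stability, read by LC-MS, using NADPH, with stated times of 10 min and 30 min, tested at 1 uM; a lower number here means slower removal, a higher number faster removal of the compound)
- compound 1 (`COC(=O)C1=C(C)NC(c2nccs2)=NC1(C)c1ccc(S(C)(=O)=O)cc1`) gives 57 mL/min/kg
- compound 2 (`COC(=O)C1=C(C)NC(c2nccs2)=NC1(C)c1ccc(F)c(F)c1`) gives 83 mL/min/kg
- compound 3 (`COC(=O)C1=C(CN2CCC(O)CC2)NC(c2nccs2)=NC1(C)c1ccc(F)cc1`) gives 81 mL/min/kg

All three values lie within the usual scatter of one another, so compound 3 stands level with both compound 1 and compound 2 and the numbers set no order among them. Compound 4 (`COC(=O)C1=C(CN(C)C2(C(=O)O)CC2)NC(c2nccs2)=NC1(C)c1ccc(F)cc1`) differs from compound 3 in one place, with a group of 8 heavy atoms (5 carbon, 1 nitrogen, 2 oxygen; one three-membered non-aromatic ring of carbon only) in place of a group of 7 heavy atoms (5 carbon, 1 nitrogen, 1 oxygen; one six-membered non-aromatic ring with 1 hetero atom), on a saturated chain carbon bound to a double-bonded ring carbon as the change. For the measured compounds named here, no two measured compounds differ in one place only, so the data give no direct guide to the size of this change. The expectation of a lower number rests on the structural change alone, and it is a modest one. Going by the values given here, the expected step is a 1.9-fold lower number from compound 3 to compound 4 (0.29 log units; within the scatter) and so about the size of the usual scatter, with no step at all still plausible. For compound 4 the estimated value is 42 mL/min/kg with an expected range from 18 mL/min/kg to 80 mL/min/kg in this measurement.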

Compound 4, clearance: 42 mL/min/kg
Estimate against measurement, compound 4: no gap at the digits printed; measured number inside the range.
By their numbers in this assay, from the lowest: compounds 4, 1, 3 and 2 (each within the scatter of the next).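

For the compounds shown here, compound 3 and compound 4 are the first pair here that differ in one place, and so they give the first reading of a change on a saturated chain carbon bound to a double-bonded ring carbon. In this assay the group of 8 heavy atoms with its three-membered non-aromatic ring of carbon only, put in place of the 4-hydroxypiperidin-1-yl group, gives a 1.9-fold lower number from compound 3 to compound 4 (0.29 log units; within the scatter) and this step lies within the scatter, so the two groups cannot be told apart on this reading. Nothing among the data shown speaks to what lies behind the step.

The carboxylic acid and the three-membered ring enter together, and the compounds shown do not separate them. Also open, from the compounds shown here alone, is how a morpholine ring or a dimethylamino group would read at this place, and whether a longer chain carrying the carboxylic acid would give a step beyond the scatter.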